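A few compounds are considered here, and "the series" means these few. Any claim that something is new, unique, unknown or untested is made for them only; others in the source may bear on it.

Measured compounds in an ADME assay on RAW264.7 cells (Mus musculus) for cytotoxicity, read by MTT assay, with a stated time of 24 h, tested at 5 ug/mL; a lower number here means a stronger effect, a higher number a weaker effect of the compound at the concentration tested:
- compound 1, `COc1ccc(C(=O)CCc2ccc(OC)c(OC)c2)c(O)c1`: 75.2%
- compound 2, `COc1ccc(C(=O)CCc2ccc(OC)c(OC)c2OC)c(O)c1`: 94.8%
- compound 3, `COc1ccc(CCC(=O)c2ccc(OC)c(OC)c2)cc1O`: 91.8%

Compound 1 holds the lowest of the three numbers in this assay; compound 3 comes nearest with a higher number, and compound 2 lies furthest with a still higher number, both gaps beyond the scatter.

Compound 4, `COc1ccc(CCC(=O)c2ccc(OC)cc2O)cc1`, has not yet been measured in this assay. Relative to compound 1 the change is hydrogen in place of methoxy on an aromatic carbon. Within the data shown here, the only measured step that bears on this change runs the other way: a number 19.6 percentage points higher from compound 1 to compound 2 (beyond the scatter), where a methoxy is added to the core of compound 1. Taking that step in reverse, a methoxy leaving compound 1 might be expected to lower the number in this assay, though the methoxy removed here sits at a different place from the one added in compound 2, and compound 3, an isomer of compound 1, shows that moving groups around this core can raise the number as well. The expectation is therefore a small decrease, possibly not beyond the scatter, with wide uncertainty.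

For compound 4 the estimate in this assay is 68%, with a range from 48% to 88%, which would mean an expected step of a number 7.2 percentage points lower from compound 1 to compound 4 (within the scatter).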

Compound 4, a percentage reported as activity, at one concentration (the size of the read-out at that concentration, not a potency): 92.3%
Compound 4: the middle estimate sits 24.3 percentage points below what was measured, outside the stated range (above it).
By their numbers in this assay, from the lowest: compound 1; then compounds 3, 4 and 2 (each within the scatter of the next).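

In this assay, hydrogen in place of methoxy on an aromatic carbon, ortho to a methoxy group and meta to a large group, gives a number 17.1 percentage points higher from compound 1 to compound 4 (beyond the scatter). The earlier step, with a methoxy added at a different place, gave a number 19.6 percentage points higher from compound 1 to compound 2 (beyond the scatter), so on the core of compound 1 both adding one methoxy and removing one raise the number, and across these two steps the read-out does not follow the count of methoxy groups in one direction. Nothing at hand explains why this position responds as it does.

Open, going by these compounds, is whether the rise at this position comes from the loss of the methoxy as such or whether any other replacement would do the same, which a chlorine or an ethoxy at the same aromatic carbon would begin to separate. Also open, on these data alone, is whether the two changes on compound 1 would add up or cancel in a single compound, and whether the number at a single concentration reflects how these compounds behave at other concentrations in this assay.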